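Swapping Chloro for Cyano at the Cytotoxicity Limit

This account rests on a few compounds, and the source may have more. Where it says the series, first, only, none or still open, it means among the compounds named here.

Compound 3 `Cc1nc(C)c([C@H](OC(C)(C)C)C(=O)O)c(N2CCC(C)(C)CC2)c1-c1ccc(OCCc2ccc(Cl)cc2)cc1` was tested in a toxicity assay on MT2 cells (Homo sapiens) for cytotoxicity, read by XTT assay, with a stated time of 4 days; on this read-out lower numbers stand for higher toxicity in this test and higher numbers for lower toxicity in this test. Compound 3 gives >= 33500 nM, which is a limit of the assay rather than a number. Compound 1 `Cc1ccc(CCOc2ccc(-c3c(C)nc(C)c([C@H](OC(C)(C)C)C(=O)O)c3N3CCC(C)(C)CC3)cc2)cc1` likewise gives >= 33500 nM, a limit. Compound 2 `COc1cccc(CCOc2ccc(-c3c(C)nc(C)c([C@H](OC(C)(C)C)C(=O)O)c3N3CCC(C)(C)CC3)cc2)c1` also gives >= 33500 nM, a limit. Because (the limit of >= 33500 nM in this assay, at which 3 of the 3 values shown sit), none of the steps among these three compounds can be read: a step that the two limits leave unreadable from compound 1 to compound 2, a step that the two limits leave unreadable from compound 1 to compound 3 and a step that the two limits leave unreadable from compound 2 to compound 3 all stay unreadable in size. Compound 4 `Cc1nc(C)c([C@H](OC(C)(C)C)C(=O)O)c(N2CCC(C)(C)CC2)c1-c1ccc(OCCc2ccc(C#N)cc2)cc1` differs from compound 3 by cyano in place of chloro on an aromatic carbon. Going by the values given here, no measured step gives a readable size, so no step beyond the scatter is expected, and the new measurement is likely to end as a limit again. Compound 4 is therefore estimated at 50000 nM, with a range from 20000 nM to 150000 nM, an expected step that the limit leaves unreadable from compound 3 to compound 4.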

Compound 4, half-maximal cytotoxic concentration: >= 33500 nM
Compound 4 ended at the assay's limit (the forecaster's own chance of this, stated with the estimate: 85%); the middle value lies beyond the limit too.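

Compound 4 sits at the assay's limit, as do compound 1, compound 2 and compound 3, so none of its steps to them can be read: the limit of >= 33500 nM in this assay, at which 4 of the 4 values shown sit. From the compounds shown here alone, whether the cyano, chloro, methyl and methoxy compounds differ at all in toxicity stays open.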